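This account rests on a few compounds, and the source may have more. Where it says the series, first, only, none or still open, it means among the compounds named here.

Measured so far in a functional assay on MGC-803 cells (Homo sapiens) for inhibition, read by sulforhodamine B assay; on this read-out lower numbers stand for stronger inhibition and higher numbers for weaker inhibition:
compound 1 `O=C1C(Nc2ccccc2)=CC(=O)c2c1nc1n2[C@H]2OC[C@@H](O)[C@H]2OC1` — 1830 nM
compound 2 `O=C1C=C(NC2CCCC2)C(=O)c2c1nc1n2[C@H]2OC[C@@H](O)[C@H]2OC1` — a limit, > 8000 nM
compound 3 `COc1ccccc1NC1=CC(=O)c2nc3n(c2C1=O)[C@H]1OC[C@@H](O)[C@H]1OC3` — 1630 nM

Compound 1 holds the highest of the two numbers; compound 3 sits within the scatter of it. The value of compound 2 is a limit of this assay, (the limit of > 8000 nM in this assay, at which 1 of the 3 values shown sits), not a number.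

Compound 4 `COc1cccc(NC2=CC(=O)c3c(nc4n3[C@H]3OC[C@@H](O)[C@H]3OC4)C2=O)c1` differs from compound 1 by methoxy in place of hydrogen on an aromatic carbon. Among the compounds with values here, the only step on record, an at least 4.9-fold lower number from compound 2 to compound 3 (0.69 log units; beyond the scatter), exchanges the whole group on the amine nitrogen and does not touch a methoxy added to a phenyl already in place; compounds 1 and 3 show that a methoxy on that phenyl gives numbers within the scatter of each other. No step beyond the scatter is therefore expected in this assay for compound 4, whose value is estimated at 1600 nM (700 nM to 3600 nM), a step of a 1.1-fold lower number from compound 1 to compound 4 (0.06 log units; within the scatter).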

Compound 4, half-maximal inhibitory concentration: 1790 nM
Estimate against measurement, compound 4: 1.1-fold (0.05 log units) below; the range from low to high includes it.
By their numbers in this assay, from the lowest: compounds 3, 4 and 1 (each within the scatter of the next). At a limit, above all of these: compound 2.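

In this assay, methoxy in place of hydrogen on an aromatic carbon, meta to a large group, gives a 1.0-fold lower number from compound 1 to compound 4 (0.01 log units; within the scatter). The phenyl of compound 1 therefore accepts 3-methoxyphenyl without a step beyond the scatter. With compound 3, which carries 2-methoxyphenyl and gives 1630 nM, two methoxy placements on this phenyl now stand within the scatter of the unsubstituted compound.

From the compounds shown here alone, whether an amine or a carboxylic acid at this position would give a step beyond the scatter stays open. Nothing at hand bears on why methoxy produces no such step here.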